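Fluoro on the phenyl ring of compound 2

The compounds below may be only part of what the source reports. "The series", "measured", "known", "first", "only" and "open" are said of these compounds alone.

Measured in an ADME assay on HEK293 cells (Homo sapiens) for cytotoxicity, read by MTT assay; a higher number here means a weaker inhibitor, a lower number a stronger inhibitor:
- compound 1 `COc1cc2ncnc(Nc3cc(O)[nH]n3)c2cc1OC` gives 69500 nM
- compound 2 `COc1cc2ncnc(Nc3cc(-c4ccccc4)[nH]n3)c2cc1OC` gives 71100 nM

Only these two compounds have been measured, so compound 2 can be placed only against compound 1. Going by the values given here, the two values lie within the scatter of each other, as the single available step shows: a 1.0-fold higher number from compound 1 to compound 2 (0.01 log units; within the scatter).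

The next compound, compound 3 `COc1cc2ncnc(Nc3cc(-c4ccc(F)cc4)[nH]n3)c2cc1OC`, differs from compound 2 by fluoro in place of hydrogen on an aromatic carbon. This is fluoro in place of hydrogen on an aromatic carbon, para to a large group.

Among the compounds with values here, no measured step covers fluoro directly. The closest evidence is a 1.0-fold higher number from compound 1 to compound 2 (0.01 log units; within the scatter), an exchange of hydroxy for phenyl that stayed within the scatter in this assay. On that single step, no shift beyond the scatter is expected, and the direction is left open. The expected step is a 1.0-fold lower number from compound 2 to compound 3 (0.02 log units; within the scatter). For compound 3 the estimated value is 68000 nM, with an expected range from 35000 nM to 125000 nM.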

Compound 3, half-maximal inhibitory concentration: < 100000 nM
Compound 3: no number, only a limit (the forecaster's own chance of this, stated with the estimate: 15%); the middle value does not contradict the limit.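

In this assay, going by these compounds alone, compound 3 gives < 100000 nM, which is a limit of the assay and not a number, so no step from compound 1 or compound 2 to compound 3 can be read. The compounds shown leave open whether fluoro in place of hydrogen on the phenyl ring of compound 2 changes the number in this assay beyond the scatter.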